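Swapping fluoro for methoxy in a cytotoxicity pair

The source may report more compounds than this note shows. Statements on the series, on what has been measured and on what is new or still open speak of the compounds shown alone.

Compound 1 `COc1c(N2CCCC2)c(F)cc2c(=O)c(C(=O)O)cn(C3CC3)c12`: 150 ug/mL
Compound 2 `O=C(O)c1cn(C2CC2)c2c(F)c(N3CCNCC3)c(F)cc2c1=O`: 47 ug/mL

Both numbers come from a functional assay on V79 cells (Cricetulus griseus) for cytotoxicity, read by colony formation; a lower number here means a stronger inhibitor, a higher number a weaker inhibitor. Compound 2 has the lower of the two values at 47 ug/mL, which makes it the stronger inhibitor, and the gap to compound 1 at 150 ug/mL is beyond the usual scatter.

Compound 3 `COc1c(N2CCNCC2)c(F)cc2c(=O)c(C(=O)O)cn(C3CC3)c12` has not yet been measured. It carries methoxy in place of fluoro on an aromatic carbon. For the measured compounds named here, no measured pair isolates this swap, so any step size is a judgement. Going by the values given here, the only guide is compound 1 at 150 ug/mL, which also carries methoxy but differs from compound 2 elsewhere too. A moderate rise is therefore expected in this assay, and the estimated step is a 2.1-fold higher number from compound 2 to compound 3 (0.33 log units; beyond the scatter). For compound 3 the expected value is 100 ug/mL, with an estimated range from 40 ug/mL to 230 ug/mL.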

Compound 3, half-maximal inhibitory concentration: 82 ug/mL
Compound 3: the middle estimate sits 1.2-fold (0.09 log units) above what was measured; measured number inside the range.
By their numbers in this assay, from the lowest: compounds 2, 3 and 1 (each within the scatter of the next, the first and the last beyond it).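

In this assay, methoxy in place of fluoro on an aromatic carbon, ortho to a fused ring, now has a step of its own, a 1.7-fold higher number from compound 2 to compound 3 (0.24 log units; within the scatter), so this single change stays within what repeat measurements would show. Compound 3 also isolates piperazin-1-yl in place of pyrrolidin-1-yl, with a 1.8-fold lower number from compound 1 to compound 3 (0.26 log units; within the scatter), which means the gap beyond the scatter between compound 1 and compound 2 splits into two single changes, neither of which exceeds the scatter alone. Nothing available explains either step.

Going by these compounds, whether a larger group on this aromatic carbon, such as ethoxy, or a hydrogen there would also stay within the scatter of compound 2 remains open. The compounds shown also hold no pair that tests the methoxy swap with pyrrolidin-1-yl in the molecule.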